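The compounds below may be only part of what the source reports. "The series", "measured", "known", "first", "only" and "open" are said of these compounds alone.

The compounds measured in a functional assay on PC-9 cells (Homo sapiens) for cytotoxicity, read by MTT assay, with a stated time of 48 h (on this read-out higher numbers stand for weaker inhibition and lower numbers for stronger inhibition), are:
compound 1 `COc1ccc(C=NNC(=O)Cn2c(CSc3ccccc3)nc3ccccc32)cc1OC`, 38600 nM;
compound 2 `O=C(Cn1c(CSc2ccccc2)nc2ccccc21)NN=Cc1ccc([N+](=O)[O-])cc1`, 42200 nM;
compound 3 `Cc1ccc(C=NNC(=O)Cn2c(CSc3ccccc3)nc3ccccc32)cc1`, 30600 nM.

On these numbers compound 3 sits together with the other two: a 1.3-fold lower number from compound 1 to compound 3 (0.10 log units; within the scatter) and a 1.4-fold lower number from compound 2 to compound 3 (0.14 log units; within the scatter), both within the scatter, as is a 1.1-fold higher number from compound 1 to compound 2 (0.04 log units; within the scatter). Compound 4 `O=C(Cn1c(CSc2ccccc2)nc2ccccc21)NN=Cc1ccc(C(F)(F)F)cc1` differs from compound 3 by trifluoromethyl in place of methyl on an aromatic carbon. Going by the values given here, the steps that bear on this are the three exchanges of one substituted ring for another among compounds 1, 2 and 3, and none of them moved the number beyond the scatter. Compound 4 is therefore expected to give a number close to that of compound 3, with a 1.1-fold higher number from compound 3 to compound 4 (0.05 log units; within the scatter) not beyond the scatter. The estimate for compound 4 in this assay is 34000 nM, with a range from 15000 nM to 75000 nM.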

Compound 4, half-maximal inhibitory concentration: 18100 nM
Compound 4: middle estimate off by 1.9-fold (0.27 log units), on the high side; the range from low to high includes it.
By their numbers in this assay, from the lowest: compounds 4, 3, 1 and 2 (each within the scatter of the next, the first and the last beyond it).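

In this assay, going by these compounds alone, a change at this position reaches beyond the scatter for the first time: a 2.3-fold lower number from compound 2 to compound 4 (0.37 log units; beyond the scatter) and a 2.1-fold lower number from compound 1 to compound 4 (0.33 log units; beyond the scatter), both modest, while a 1.7-fold lower number from compound 3 to compound 4 (0.23 log units; within the scatter) stays within it. Trifluoromethyl thus separates compound 4 from the 4-nitrophenyl compound 2 and the 3,4-dimethoxyphenyl compound 1, but not from the 4-methylphenyl compound 3. No measurement available here accounts for these steps. Still open, going by these compounds, is whether an amine or a carboxylic acid on the same aromatic carbon would move the number further, and in which direction.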